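Notes on amide exchange and mouse microsomal clearance

This account rests on a few compounds, and the source may have more. Where it says the series, first, only, none or still open, it means among the compounds named here.

Measured so far:
Compound 1 `C[C@H](NC(=O)[C@@H]1CCCN1C)c1ccc(NC(=O)N2CC(c3cccnc3)C2)cc1` gives 40.8 mL.min-1.g-1 in an ADME assay on microsomes from liver (Mus musculus) for pharmacokinetics, read by LC-MS, using NADPH, with stated times of 5 min, 15 min and 30 min, tested at 10 uM; a lower number here means slower removal, a higher number faster removal of the compound.
Compound 2 `CCC(=O)N[C@@H](C)c1ccc(NC(=O)N2CC(c3cccnc3)C2)cc1` gives 31.4 mL.min-1.g-1.
Compound 3 `C[C@H](NC(=O)[C@@H]1CCCN1C)c1ccc(NC(=O)N2CC(c3cncc(N)c3)C2)cc1` gives 47.4 mL.min-1.g-1.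

Compound 2 differs from compound 1 by ethyl in place of 1-methylpyrrolidin-2-yl on a carbonyl carbon. The step of a 1.3-fold lower number from compound 1 to compound 2 (0.11 log units; within the scatter). Compound 3 differs from compound 1 in the core, by amino in place of hydrogen on an aromatic carbon, and the step of a 1.2-fold higher number from compound 1 to compound 3 (0.07 log units; within the scatter). All three numbers therefore sit within the scatter of one another, and no order among them is read from these data.

Compound 4 `CCC(=O)N[C@@H](C)c1ccc(NC(=O)N2CC(c3cncc(N)c3)C2)cc1` has not yet been run in this assay. It differs from compound 3 by ethyl in place of 1-methylpyrrolidin-2-yl on a carbonyl carbon, which is the same change, at the same place, as that from compound 1 to compound 2; the cores of compound 3 and compound 4 differ from those of compound 1 and compound 2 as described above. For the measured compounds named here, only that one precedent is available, and it lies within the scatter, so the number for compound 4 is expected to stay close to that of compound 3, with an expected step of a 1.3-fold lower number from compound 3 to compound 4 (0.11 log units; within the scatter) resting on a 1.3-fold lower number from compound 1 to compound 2 (0.11 log units; within the scatter). Compound 4 is estimated at 36.5 mL.min-1.g-1, expected between 20 mL.min-1.g-1 and 65 mL.min-1.g-1.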

Compound 4, intrinsic clearance in microsomes: 56.9 mL.min-1.g-1
Beside the measured number, compound 4's estimate is 1.6-fold (0.19 log units) below it, within the range that was stated.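

In this assay, ethyl in place of 1-methylpyrrolidin-2-yl on a carbonyl carbon gives a 1.2-fold higher number from compound 3 to compound 4 (0.08 log units; within the scatter), and this step does not differ from its precedent on the other core: the same change on two cores in this assay, a 1.3-fold lower number (0.11 log units; within the scatter) from compound 1 to compound 2 and a 1.2-fold higher number (0.08 log units; within the scatter) from compound 3 to compound 4, 1.6-fold (0.19 log units) apart, within the scatter of two such steps

Amino in place of hydrogen on an aromatic carbon, read with ethyl on the carbonyl carbon, gives a 1.8-fold higher number from compound 2 to compound 4 (0.26 log units; within the scatter), and this step also does not differ from its precedent: the same change on two cores in this assay, a 1.2-fold higher number (0.07 log units; within the scatter) from compound 1 to compound 3 and a 1.8-fold higher number (0.26 log units; within the scatter) from compound 2 to compound 4, 1.6-fold (0.19 log units) apart, within the scatter of two such steps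

Each change therefore carries between these two cores with no difference that can be read, but every step lies within the scatter, so the agreement concerns small steps only and does not show that either change has a real effect on removal or would carry to any further core.

Still open, as far as these compounds go, is whether a step beyond the scatter appears with a longer chain or a primary amine on the carbonyl carbon. The same question stands for a nitrile in place of amino on the aromatic carbon.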